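A few compounds are considered here, and "the series" means these few. Any claim that something is new, unique, unknown or untested is made for them only; others in the source may bear on it.

Values in a functional assay on brain (Rattus norvegicus, strain Wistar) for inhibition (a lower number here means a stronger inhibitor, a higher number a weaker inhibitor), so far
compound 1 `CCCCc1ccc(-c2c(C)[nH]c(=O)n2C)cc1` gives 10700 nM
compound 2 `CCCCOc1ccc(-c2c(C)[nH]c(=O)n2C)cc1` gives 5100 nM
compound 3 `CCCCOc1ccc(-c2c(C)[nH]c(=O)n2C2CCCCC2)cc1` gives 13900 nM

In this assay compound 2 (at 5100 nM) has the lowest of the three numbers, and both other compounds lie beyond the scatter from it. The unmeasured compound 4 `COc1ccc(-c2c(C)[nH]c(=O)n2C)cc1` is compound 2 with butoxy cut to methoxy (hydrogen in place of propyl on a saturated chain carbon bound to an oxygen on an aromatic ring), that is, hydrogen in place of propyl on a saturated chain carbon bound to an oxygen on an aromatic ring.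

Among the measured compounds shown here, no measured step shortens this chain, so the evidence is indirect. The closest is butoxy in place of butyl on an aromatic carbon (a 2.1-fold lower number from compound 1 to compound 2 (0.32 log units; beyond the scatter)), which shows that the group at this end of the molecule moves the number, though only modestly. The other step (a 2.7-fold higher number from compound 2 to compound 3 (0.44 log units; beyond the scatter)) lies on an aromatic nitrogen and bears on this change only as a guide to size. Since most of the butoxy group goes, a step of similar or somewhat larger size is expected, towards a higher number, but the direction is not firmly fixed by these data. Compound 4 is expected at 12000 nM (expected range 4500 nM to 35000 nM). The estimated step is a 2.4-fold higher number from compound 2 to compound 4 (0.37 log units; beyond the scatter) (an expectation only).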

Compound 4, half-maximal inhibitory concentration: 147000 nM
Compound 4: the middle estimate sits 12-fold (1.09 log units) below what was measured, and the stated range ends below it.
By their numbers in this assay, from the lowest: compound 2; then compounds 1 and 3 (each within the scatter of the next); then compound 4.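

In this assay the propyl part of the butoxy group carries far more of the number than the modest butoxy-for-butyl step suggested, as cutting butoxy to methoxy gives a large change (a 29-fold higher number from compound 2 to compound 4 (1.46 log units; beyond the scatter)). The step from butyl to methoxy is also large and runs the same way (a 14-fold higher number from compound 1 to compound 4 (1.14 log units; beyond the scatter)), so among these compounds the two with a butyl chain, whether joined directly or through the oxygen, both have much lower numbers than the methoxy compound, and the presence of that chain counts for more here than the oxygen does. Nothing measured here explains why removing the propyl part costs so much.

The compounds shown leave open how the number runs between methoxy and butoxy, and whether a longer chain such as hexyloxy or a ring-bearing group such as benzyloxy would lower it further. They also leave open whether the same large rise on going to methoxy would hold with cyclohexyl in place of methyl on the aromatic nitrogen.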